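Swapping Cyclohexyl for Methylthiazolyl on the Cyclopropane Ring

This account rests on a few compounds, and the source may have more. Where it says the series, first, only, none or still open, it means among the compounds named here.

Of the compounds shown here, three have been tested in a functional assay for agonist activity at G protein-coupled receptor 88 (Homo sapiens), read by HTRF and cAMP accumulation; a lower number here means that less compound is needed, a higher number that more compound is needed for the effect. Compound 1 `CO[C@H](C)[C@H](N)CN(C(=O)[C@@H]1C[C@H]1c1ccccc1)c1ccc(-c2ccccc2)cc1` gives 0.68 nM. Compound 2 `CC(C)(N)CN(C(=O)[C@@H]1C[C@H]1c1ccccc1)c1ccc(-c2ccccc2)cc1` gives 1.4 nM, a modest step of a 2.1-fold higher number from compound 1 to compound 2 (0.31 log units; beyond the scatter). Compound 3 `CC[C@H](C)[C@H](N)CN(C(=O)[C@@H]1C[C@H]1C1CCCCC1)c1ccc(-c2ccccc2)cc1` reaches only the assay limit of > 25000 nM, so no number is known for it; it sits at the limit of > 25000 nM in this assay, at which 1 of the 3 values shown sits. Compound 4 `CC[C@H](C)[C@H](N)CN(C(=O)[C@@H]1C[C@H]1c1nc(C)cs1)c1ccc(-c2ccccc2)cc1` differs from compound 3 by 4-methyl-1,3-thiazol-2-yl in place of cyclohexyl on a saturated ring carbon. For the measured compounds named here, no measured step covers this change, and the single measured step concerns another part of the core. Compounds 1 and 2 also differ from compound 3 in this part of the molecule; compound 1 reaches 0.68 nM and compound 2 reaches 1.4 nM. A large gain toward such values is therefore expected, an at least 500-fold lower number from compound 3 to compound 4 (2.69 log units; beyond the scatter). Compound 4 is estimated at 50 nM, between 3 nM and 3000 nM.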

Compound 4, half-maximal effective concentration: 730 nM
Estimate against measurement, compound 4: 15-fold (1.16 log units) below; low and high end bracket the measured number.
By their numbers in this assay, from the lowest: compound 1; then compound 2; then compound 4. At a limit, above all of these: compound 3.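

In this assay, the group on this saturated ring carbon of the three-membered ring decides whether a number can be read at all, with an at least 34-fold lower number from compound 3 to compound 4 (1.53 log units; beyond the scatter). Compound 3 stays at a limit of the assay, not a number: the limit of > 25000 nM in this assay, at which 1 of the 4 values shown sits. For the compounds shown here, the step therefore gives only a minimum size, yet it is the first measured change at this position and shows that 4-methyl-1,3-thiazol-2-yl is tolerated far better than cyclohexyl. Still open, as far as these compounds go, is whether the methyl on the thiazole matters, and whether a plain thiazol-2-yl or a pyridin-2-yl ring would behave alike.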